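Alkoxy chain variation on the aminoquinoline series

This account rests on a few compounds, and the source may have more. Where it says the series, first, only, none or still open, it means among the compounds named here.

Measured so far:
- Compound 1, `COCC(C)Oc1cccc2ccc(N)nc12`: 606 nM in an assay on cells with melanin-concentrating hormone receptor 1 (Homo sapiens) as the target, read by radioligand binding; a lower number here means a stronger inhibitor, a higher number a weaker inhibitor
- Compound 2, `CC(C)(C)CCOc1cccc2ccc(N)nc12`: 201 nM in this assay

Within the data shown here, compound 2 holds the lowest number of the two, and its one neighbour on the table is compound 1, with a 3.0-fold lower number from compound 1 to compound 2 (0.48 log units; beyond the scatter) separating them by 3,3-dimethylbutyl in place of 1-(methoxymethyl)ethyl on an oxygen on an aromatic ring.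

Compound 3, `CSCCOc1cccc2ccc(N)nc12`, is not yet measured. It differs from compound 2 by methylsulfanyl in place of tert-butyl on a saturated chain carbon, two bonds along the chain from an oxygen on an aromatic ring. Among the measured compounds shown here, the only step that bears on it is a 3.0-fold lower number from compound 1 to compound 2 (0.48 log units; beyond the scatter), where the branched ether chain of compound 1 carried the higher number and the all-carbon chain of compound 2 the lower one. Compound 3 again puts a heteroatom acceptor into the chain and removes the tert-butyl, so a move back toward the number of compound 1 is expected: an estimated 2.7-fold higher number from compound 2 to compound 3 (0.44 log units; beyond the scatter), toward a weaker inhibitor. Compound 3 is therefore expected at about 550 nM, within the range 200 nM to 1500 nM.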

Compound 3, half-maximal inhibitory concentration: > 2000 nM
Compound 3 was reported as a limit; the forecaster's own chance of this, stated with the estimate: 5%; middle value at least 3.6-fold (0.56 log units) from the limit.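

Compound 3 is reported only as a limit, not as a number: the limit of > 2000 nM in this assay, at which 1 of the 3 values shown sits.

Methylsulfanyl in place of tert-butyl on the saturated chain carbon gives an at least 9.9-fold higher number from compound 2 to compound 3 (0.99 log units; beyond the scatter), and that figure is a floor rather than a size. The 2-(methylsulfanyl)ethyl chain also falls short of the branched ether chain, with an at least 3.3-fold higher number from compound 1 to compound 3 (0.51 log units; beyond the scatter), so the number of compound 1 does not mark the upper end for this position.

From the compounds shown here alone, the true size of both steps stays open, and the three chains differ in branching, length and heteroatom together, so none of these is separated from the others. Whether the sulfur itself matters, or the loss of the tert-butyl, remains unsettled, as does where a 2-methoxyethyl chain or a plain butyl chain would fall relative to compound 2 and compound 3.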